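A few compounds are considered here, and "the series" means these few. Any claim that something is new, unique, unknown or untested is made for them only; others in the source may bear on it.

Compound 1 `Cc1noc(-c2nc(C)c3c(c2N)C(=O)N(Cc2ccccc2)C3=O)n1` gives < 5000 nM in a physicochemical assay for solubility, using the shake flask method, in simulated intestinal fluid, measured as kinetic solubility, with a stated time of 2 h, at 25 degrees C, at pH 6.5 (on this read-out lower numbers stand for lower solubility and higher numbers for higher solubility), and this is a limit of the assay rather than a number. Compound 2 `Cc1noc(-c2nc(C)c3c(c2N)C(=O)N(Cc2ccc(C(F)(F)F)cc2)C3=O)n1` gives < 5000 nM in this assay, again only a limit.

On the numbers shown, compound 2 therefore stands nowhere more exactly than at that limit; both values shown share it, as the limit of < 5000 nM in this assay, at which 2 of the 2 values shown sit, states. Among the measured compounds shown here, the single measured step, a step that the two limits leave unreadable from compound 1 to compound 2, runs from one limit to another, so its size and direction cannot be read. Compound 3 `Cc1noc(-c2nc(C)c3c(c2N)C(=O)N(Cc2ccc(SC(F)(F)F)cc2)C3=O)n1` is not yet measured and differs from compound 2 by (trifluoromethyl)sulfanyl in place of trifluoromethyl on an aromatic carbon. For the measured compounds named here, the only measured step that bears on this change is a step that the two limits leave unreadable from compound 1 to compound 2. That step is unreadable, and it offers no size and no direction for the new step. With nothing read beyond the limit for either measured compound, compound 3 is expected to remain at or near that same limit, so the step that the limit leaves unreadable from compound 2 to compound 3 is estimated to be small or to stay unreadable. In this assay compound 3 is thus estimated at 2000 nM, within a range from 300 nM to 5000 nM.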

Compound 3, solubility: < 5000 nM
Compound 3: only a limit was reported (the forecaster's own chance of this, stated with the estimate: 85%); the middle value does not contradict the limit.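

In this assay compound 3 gives < 5000 nM, which is a limit and not a number. Neither new step, from compound 2 or from compound 1 to compound 3, can be read, as each runs between limits: the limit of < 5000 nM in this assay, at which 3 of the 3 values shown sit.

The compounds shown leave open how the solubilities of compound 1, compound 2 and compound 3 compare, and how far each lies beneath the shared limit.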